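The compounds below may be only part of what the source reports. "The series", "measured", "known", "first", "only" and "open" are said of these compounds alone.

Among the measured compounds shown here, the three compounds measured so far share one core and differ at the aromatic nitrogen and in the ester. Compound 1 `CCOC(=O)c1cccc(-c2n[nH]c3ccccc23)c1` was tested in a functional assay on cells (Platelet, Homo sapiens) for inhibition; a higher number here means a weaker inhibitor, a lower number a stronger inhibitor; in this assay compound 1 gives only a limit, > 10000 nM. Compound 3 `COC(=O)c1ccc(-c2nn(Cc3ccccc3)c3ccccc23)cc1` likewise reaches only a limit in this assay, > 10000 nM. Compound 2 `CCOC(=O)c1ccc(-c2nn(Cc3ccccc3Cl)c3ccccc23)cc1` also gives only a limit in this assay, > 10000 nM. Compound 2 therefore stands at the limit of > 10000 nM in this assay, at which 3 of the 3 values shown sit, with no number of its own to separate it from the others. The unmeasured compound 4 `CCOC(=O)c1ccc(-c2nn(-c3ccccc3)c3ccccc23)cc1` differs from compound 2 in one place: phenyl in place of 2-chlorobenzyl on an aromatic nitrogen. For the measured compounds named here, no step between two measured compounds is available, so the effect of this change cannot be read from the data. With every measured value sitting at the limit, the expected step in this assay is a step that the limit leaves unreadable from compound 2 to compound 4, nothing beyond the usual scatter. Compound 4 is expected to give about 15000 nM in this assay, in a range from 5000 nM to 50000 nM, most likely reported again only as a limit.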

Compound 4, half-maximal inhibitory concentration: > 10000 nM
Compound 4 gave a limit, no number; the forecaster's own chance of this, stated with the estimate: 85%; the middle value does not contradict the limit.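

Compound 2 and compound 4 both give only a limit, so no step can be read for phenyl in place of 2-chlorobenzyl on an aromatic nitrogen: the limit of > 10000 nM in this assay, at which 4 of the 4 values shown sit. The compounds shown leave open what change to the shared core, if any, would give a measured number in this assay.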